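Removing the Acetylated Piperidine from Compound 2

The source may hold more compounds than are shown below. What is called first, only, known or untested is meant among the compounds shown, and "the series" means these compounds.

Of the compounds shown here, two built on a shared core have been measured in a functional assay on MKN-45 cells (Homo sapiens) for antiproliferative activity, read by CellTiter-Glo, with a stated time of 3 days; on this read-out lower numbers stand for stronger inhibition and higher numbers for weaker inhibition. Compound 1 `CC(Oc1c(N)ncc2c(-c3cnn(C4CCNCC4)c3)coc12)c1c(Cl)cccc1Cl` gives 2000 nM. Compound 2 `CC(=O)N1CCC(n2cc(-c3coc4c(O[C@H](C)c5c(Cl)ccc(F)c5Cl)c(N)ncc34)cn2)CC1` gives 670 nM, the lower of the two numbers, and the gap between them lies beyond the scatter. Compound 3 `C[C@@H](Oc1c(N)ncc2c(-c3cn[nH]c3)coc12)c1c(Cl)ccc(F)c1Cl` departs from compound 2 in one place: hydrogen in place of 1-acetylpiperidin-4-yl on an aromatic nitrogen. In words, it carries hydrogen in place of 1-acetylpiperidin-4-yl on an aromatic nitrogen. Going by the values given here, no measured pair shows this change alone, so the data give no direct guide to its size in this assay. A modest move towards stronger inhibition is expected, although a result within the scatter would fit equally well. The estimated change is a 1.7-fold lower number from compound 2 to compound 3 (0.22 log units; within the scatter). For compound 3 the expected value is 400 nM, with an estimated range from 100 nM to 1600 nM.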

Compound 3, half-maximal inhibitory concentration: 3300 nM
Compound 3: the middle estimate sits 8.3-fold (0.92 log units) below what was measured; measured number outside the range, above it.
By their numbers in this assay, from the lowest: compound 2; then compounds 1 and 3 (each within the scatter of the next).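

In this assay, replacing the 1-acetylpiperidin-4-yl on the aromatic nitrogen with hydrogen gives a 4.9-fold higher number from compound 2 to compound 3 (0.69 log units; beyond the scatter) and so weaker inhibition. Going by these compounds alone, this is the first direct reading at this place on the five-membered aromatic ring, and it shows that the substituent there matters for this read-out: within this pair, stronger inhibition goes with the group that carries the six-membered non-aromatic ring. Nothing available explains the shift.

Which part of the leaving group accounts for the difference remains open, as the acetyl and the piperidine ring have not been separated on an otherwise identical compound. On these data alone, it is also open whether a methyl group, a morpholine ring or a short chain ending in a carboxylic acid on that nitrogen would match compound 2 or surpass it.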